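The source may report more compounds than this note shows. Statements on the series, on what has been measured and on what is new or still open speak of the compounds shown alone.

Measured compounds:
- compound 1, `O=C(O)CC1CCCC1Cc1ccc(OCc2ccc3ccccc3n2)cc1`, giving 100 nM
- compound 2, `CC(CCCC(=O)O)c1cccc(OCc2ccc3ccccc3n2)c1`, giving 90 nM

Both compounds were tested in an assay on membranes from lung (Cavia porcellus) for binding affinity to cysteinyl leukotriene receptor (Homo sapiens); a higher number here means a weaker inhibitor, a lower number a stronger inhibitor. Compound 2 has the lowest of the two numbers, but its nearest neighbour is compound 1, and the gap between the two falls within the scatter, so the two cannot be told apart on these numbers. Both share the same core, a quinoline-type methyl ether on a benzene ring, and differ in the acid-bearing chain attached to that ring.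

Compound 3, `CC(CCCc1cccc(OCc2ccc3ccccc3n2)c1)C(=O)O`, has not yet been tested in this assay. It is built from exactly the same atoms as compound 2, joined differently: 4-carboxypentyl in place of 4-carboxy-1-methylbutyl on an aromatic carbon. The change only moves a single branch along the 4-carboxypentyl chain, leaving the acid, the chain length and the point of attachment to the ring as they were.

Among the compounds with values here, no step between measured compounds is available to say how such a rearrangement plays out. With nothing in the data to point either way, the step of a 1.3-fold higher number from compound 2 to compound 3 (0.12 log units; within the scatter) is expected to be small, within the scatter. Compound 3 is therefore estimated at 120 nM, with a range from 40 nM to 360 nM.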

Compound 3, inhibition constant: 85 nM
Beside the measured number, compound 3's estimate is 1.4-fold (0.15 log units) above it; the range from low to high includes it.
By their numbers in this assay, from the lowest: compounds 3, 2 and 1 (each within the scatter of the next).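

In this assay, within the data shown here, 4-carboxypentyl in place of 4-carboxy-1-methylbutyl on an aromatic carbon gives a 1.1-fold lower number from compound 2 to compound 3 (0.02 log units; within the scatter), the first change here that can be read at a single place in the structure. This is a useful result even though the numbers barely differ: with the same atoms and the same point of attachment to the ring, the two arrangements of the chain cannot be told apart in this measurement. It shows only that this one rearrangement leaves the number within the scatter, and nothing shown here gives a reason for that.

From the compounds shown here alone, whether the methyl branch matters at all remains open, and a comparison with an unbranched 4-carboxybutyl chain, or with a branch made from an ethyl group, would address that question. A longer chain, or an amide or a tetrazole in place of the carboxylic acid, would show whether this position stays as undemanding once the chain length or the acid itself is changed.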